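The source may report more compounds than this note shows. Statements on the series, on what has been measured and on what is new or still open speak of the compounds shown alone.

Going by the values given here, compound 2, with structure `O=C(NCCCCc1ccccc1)c1cccc(C2SCC(=O)N2c2cccc(F)c2)c1`, is one of three compounds measured in a functional assay on MG-63 cells (Homo sapiens) for inhibition, read by CCK-8 assay, with a stated time of 72 h, tested at 1 uM (a higher number here means more inhibition at the concentration tested (going by the name of the read-out), a lower number less inhibition), where compound 2 gives 92%. Compound 1, with structure `COc1ccc(C)cc1N1C(=O)CSC1c1cccc(C(=O)NCCCCc2ccccc2)c1`, gives 92% in this assay, and the two values are level within the scatter, so together they are the highest of the three numbers. Compound 3, with structure `O=C(NCCCCc1ccccc1)c1cccc(C2OCC(=O)N2c2cccc(F)c2)c1`, gives 66% in this assay, a lower number that lies beyond the scatter from the other two. Among the compounds with values here, the one measured step that changes a group on the aryl attached to the ring nitrogen, no change at the digits printed from compound 1 to compound 2 (within the scatter), shows no change beyond the scatter.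

Compound 4, with structure `CC(F)(F)c1cccc(N2C(=O)CSC2c2cccc(C(=O)NCCCCc3ccccc3)c2)c1`, differs from compound 2 in one place: 1,1-difluoroethyl in place of fluoro on an aromatic carbon. Within the data shown here, the only comparable step, the one from compound 1 to compound 2, swaps groups on this same aryl ring without moving the number, so little change is expected in this assay. Compound 4 is expected to give about 88% in this assay, within a range from 75% to 96%, meaning an expected step of a number 4 percentage points lower from compound 2 to compound 4 (within the scatter), which lies within the scatter.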

Compound 4, a percentage reported as inhibition, at one concentration (the size of the read-out at that concentration, not a potency): 92%
Beside the measured number, compound 4's estimate is 4 percentage points below it; measured number inside the range.
By their numbers in this assay, from the lowest: compound 3; then compounds 1, 2 and 4 (each within the scatter of the next).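

In this assay, the aromatic carbon meta to a large group accepts 1,1-difluoroethyl, with 4 heavy atoms, in place of fluoro, with 1 heavy atom, and the step reads no change at the digits printed from compound 2 to compound 4 (within the scatter). Going by these compounds alone, this is the first change made at this one position alone, and the comparison of the whole groups on the ring nitrogen reads no change at the digits printed from compound 1 to compound 4 (within the scatter), so three different aryl groups on the shared core now stand level. Nothing measured here offers an explanation for this flat result.

From the compounds shown here alone, whether an amine or a carboxylic acid at this position would also leave the number in place remains open. Going by these compounds, each number is also a reading at one concentration rather than a potency, so whether compounds 1, 2 and 4 would separate at other concentrations is unknown.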